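The source may report more compounds than this note shows. Statements on the series, on what has been measured and on what is new or still open speak of the compounds shown alone.

Measured so far:
Compound 1, `CCCC(=O)O[C@]12C=CC(=O)C[C@H]1OCC2`: 0.6 ug/mL in a functional assay on P388 cells (Mus musculus) for cytotoxicity; a higher number here means a weaker inhibitor, a lower number a stronger inhibitor
Compound 2, `O=C1C=C[C@]2(OC(=O)c3ccccc3)CCO[C@@H]2C1`: 0.5 ug/mL in this assay

Compound 2 has the lower of these two numbers, but the step of a 1.2-fold lower number from compound 1 to compound 2 (0.08 log units; within the scatter) is within the scatter, so the two compounds cannot be told apart. Compound 3, `O=C1C=C[C@]2(OC(=O)c3ccc(Cl)cc3)CCO[C@@H]2C1`, differs from compound 2 by chloro in place of hydrogen on an aromatic carbon. Among the measured compounds shown here, only one measured step exists, and it touches the same part of the molecule: the step of a 1.2-fold lower number from compound 1 to compound 2 (0.08 log units; within the scatter) shows that exchanging the whole group on the carbonyl carbon left this assay unchanged within the scatter. For the measured compounds named here, no measured step tests a chloro on that ring, so there is no basis for expecting a step beyond the scatter in either direction. Compound 3 is therefore expected to give 0.5 ug/mL in this assay, within a range from 0.2 ug/mL to 1.2 ug/mL. For compound 3 the estimated step is no change at the digits printed from compound 2 to compound 3 (within the scatter), expected to stay within the scatter.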

Compound 3, half-maximal inhibitory concentration: 0.7 ug/mL
Beside the measured number, compound 3's estimate is 1.4-fold (0.15 log units) below it, and the stated range covers the measured number.
By their numbers in this assay, from the lowest: compounds 2, 1 and 3 (each within the scatter of the next).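

The first change made on the aromatic ring itself, chloro in place of hydrogen on the carbon para to a large group, gives a 1.4-fold higher number from compound 2 to compound 3 (0.15 log units; within the scatter) in this assay. The earlier step swapped the whole group on the carbonyl carbon, whereas this one shows that a single chlorine added at this ring position leaves the number indistinguishable from that of the parent compound. Nothing available here explains this result or links it to any property of the chloro group.

As far as these compounds go, whether an amine or a carboxylic acid on this same carbon would move the number beyond the scatter remains open. So does whether a chloro on another carbon of the ring would behave as this one does.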